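Methyl loss on the aryl ring of a thiazoline-pyrazoline series

The source may report more compounds than this note shows. Statements on the series, on what has been measured and on what is new or still open speak of the compounds shown alone.

Measured so far:
compound 1 `Cc1ccc(C2=NN(C3=NC(c4ccccc4)CS3)C(c3ccc4ccccc4c3)C2)cc1`, 2460 nM
compound 2 `c1ccc(C2=NN(C3=NC(c4ccccc4)CS3)C(c3ccc4ccccc4c3)C2)cc1`, 3860 nM
compound 3 `Cc1ccc(C2=NN(C3=NC(c4ccccc4)CS3)C(c3cccc4ccccc34)C2)cc1C`, 1720 nM

In a functional assay on HeLa cells (Homo sapiens) for inhibition, read by CCK-8 assay, with a stated time of 48 h (on this read-out higher numbers stand for weaker inhibition and lower numbers for stronger inhibition), compound 1 gives 2460 nM and compound 2 gives 3860 nM; the change between them, (hydrogen in place of methyl on an aromatic carbon), produced a 1.6-fold higher number from compound 1 to compound 2 (0.20 log units; within the scatter). Compound 3 gives 1720 nM. The difference between the core of compound 3 and that of compound 1 is not broken down here. Compound 4 `Cc1ccc(C2=NN(C3=NC(c4ccccc4)CS3)C(c3cccc4ccccc34)C2)cc1` is not yet measured; it differs from compound 3 by hydrogen in place of methyl on an aromatic carbon. This is the same kind of change as that from compound 1 to compound 2, though here the place is ortho to a methyl group and meta to a large group rather than para to a large group. Since the earlier step gave a 1.6-fold higher number from compound 1 to compound 2 (0.20 log units; within the scatter), a step of similar size, a 1.5-fold higher number from compound 3 to compound 4 (0.18 log units; within the scatter), is expected. For compound 4 in this assay an estimate of 2600 nM is given.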

Compound 4, half-maximal inhibitory concentration: 4290 nM
Compound 4: the middle estimate sits 1.7-fold (0.22 log units) below what was measured; the range from low to high includes it.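

Hydrogen in place of methyl, here 3,4-dimethylphenyl to 4-methylphenyl, gave a 2.5-fold higher number from compound 3 to compound 4 (0.40 log units; beyond the scatter) in this assay, and this step points the same way as the earlier one on the other core, with no difference between the two beyond the scatter: the same change on two cores in this assay, a 1.6-fold higher number (0.20 log units; within the scatter) from compound 1 to compound 2 and a 2.5-fold higher number (0.40 log units; beyond the scatter) from compound 3 to compound 4, 1.6-fold (0.20 log units) apart, within the scatter of two such steps. This shows that the change carried over between these two cores, but two pairs, with the methyl at a different place in each, fix neither a general size nor a reason for it. The swap between the cores gave a 1.7-fold higher number from compound 1 to compound 4 (0.24 log units; within the scatter) and so shows no clear effect of its own.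

From the compounds shown here alone, whether a methoxy group, a chlorine atom or an amine in place of that methyl would follow the same course remains open. So does the behaviour of the change on any further core.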